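Compound 4 as the Stereochemically Undefined Counterpart of Compound 1

This account rests on a few compounds, and the source may have more. Where it says the series, first, only, none or still open, it means among the compounds named here.

Compound 1 `C[C@@H](Oc1ccccc1)[C@@H]1CCCN1C`: 1300 nM
Compound 2 `CN1CCC[C@H]1COc1cncc(O)c1`: 235 nM
Compound 3 `COc1ccc(O)cc1OC[C@@H]1CCCN1`: 7700 nM

All three numbers come from an assay on HEK293 cells for displacement of a labelled ligand from Neuronal acetylcholine receptor; alpha3/beta4 (Homo sapiens), read by scintillation counting; on this read-out lower numbers stand for stronger inhibition and higher numbers for weaker inhibition. Among them compound 1 holds the second highest value: compound 2 sits at a lower number, a gap beyond the scatter, and compound 3 sits at a higher number, a gap that is also beyond the scatter. Going by the values given here, no two of the measured compounds differ in only one place, so no single step among them can be read off.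

Compound 4 `CC(Oc1ccccc1)C1CCCN1C` is related to compound 1 as follows: the two compounds have the same atoms and bonds; at least one stereo element is drawn with a configuration in one of them and without one in the other: 2 of 2 stereo elements differ; a stereocentre at a saturated chain carbon is drawn R in compound 1 and without a configuration in compound 4; a stereocentre at a saturated ring carbon is drawn S in compound 1 and without a configuration in compound 4. Nothing enters and nothing leaves; compound 4 is simply drawn with both stereocentres undefined, so it stands for the material of compound 1 together with its other stereoisomers, none of which has a number here. Because compound 1 gives 1300 nM and would form part of such a mixture, the step from compound 1 to compound 4 is expected to be small and directed toward a higher number, quite possibly within the scatter, estimated as a 1.7-fold higher number from compound 1 to compound 4 (0.23 log units; within the scatter). In this assay compound 4 is therefore expected at 2200 nM, within a range from 900 nM to 6500 nM.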

Compound 4, inhibition constant: 1400 nM
Estimate against measurement, compound 4: 1.6-fold (0.20 log units) above; measured number inside the range.
By their numbers in this assay, from the lowest: compound 2; then compounds 1 and 4 (each within the scatter of the next); then compound 3.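

Going by these compounds alone, compounds 1 and 4 give the first single step, and in this assay it is a 1.1-fold higher number from compound 1 to compound 4 (0.03 log units; within the scatter). The numbers therefore do not distinguish the drawing with both stereocentres defined from the drawing with both undefined, so whatever other stereoisomers compound 4 may stand for, they do not carry its number beyond the scatter from that of compound 1. This comparison concerns stereochemical drawing alone, with no group entering or leaving, and it rests on a single feature of the pair: the fact that one of compounds 1 and 4 is drawn with a defined configuration and the other without, at the place where they differ

The compounds shown leave open how each separate stereoisomer behaves, and how much the saturated chain carbon and the saturated ring carbon each contribute, since the step changes both stereocentres at once and the composition of compound 4 is not given. They also leave open how the number would respond to a fluorine or a longer chain on the core of compound 1, and whether such a change would matter more than the stereochemical drawing does here.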